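An Isopropyl Group on the Anilino Nitrogen of Compound 1

The source may hold more compounds than are shown below. What is called first, only, known or untested is meant among the compounds shown, and "the series" means these compounds.

For the measured compounds named here, compound 1 `Nc1nc(N)c2nc(Nc3ccccc3)ccc2n1` gives 1530 nM in an ADME assay on isolated protein for inhibition of Dihydrofolate reductase (Homo sapiens), using NADPH (a lower number here means a stronger inhibitor, a higher number a weaker inhibitor), the lowest of the three numbers so far, although compound 3 `Nc1nc(N)c2nc(Nc3ccc(O)cc3)ccc2n1` with 1580 nM and compound 2 `Cc1ccc(Nc2ccc3nc(N)nc(N)c3n2)cc1` with 2630 nM both lie within the scatter of it. The steps of a 1.7-fold higher number from compound 1 to compound 2 (0.24 log units; within the scatter) and a 1.0-fold higher number from compound 1 to compound 3 (0.01 log units; within the scatter) concern the aromatic ring, as does a 1.7-fold lower number from compound 2 to compound 3 (0.22 log units; within the scatter). Compound 4 `CC(C)N(c1ccccc1)c1ccc2nc(N)nc(N)c2n1` carries a different kind of change: isopropyl in place of hydrogen on a nitrogen on an aromatic ring. Going by the values given here, no measured step touches this nitrogen, so the three small steps on the aromatic ring give no direct guide, and a step in either direction beyond the scatter cannot be ruled out. Compound 4 is therefore estimated at 900 nM, within 200 nM to 4000 nM, which would mean an expected step of a 1.7-fold lower number from compound 1 to compound 4 (0.23 log units; within the scatter).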

Compound 4, half-maximal inhibitory concentration: 1370 nM
Estimate against measurement, compound 4: 1.5-fold (0.18 log units) below; the measured number falls inside the stated range.
By their numbers in this assay, from the lowest: compounds 4, 1, 3 and 2 (each within the scatter of the next).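

Placing isopropyl on a nitrogen on an aromatic ring in place of hydrogen gives a 1.1-fold lower number from compound 1 to compound 4 (0.05 log units; within the scatter) in this assay. The earlier compounds shown here showed only changes on an aromatic carbon, and this step shows that the hydrogen on this nitrogen can give way to a group of 3 heavy atoms with the number staying within the scatter. No measurement shown offers an explanation for this result. As far as these compounds go, what remains open is whether a longer chain or a carboxylic acid on this nitrogen would also stay within the scatter, and whether isopropyl there would do so alongside hydroxy or methyl on the aromatic ring.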